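Adding a Cyano Group to the Shared Core

The source may hold more compounds than are shown below. What is called first, only, known or untested is meant among the compounds shown, and "the series" means these compounds.

Of the compounds shown here, two sharing one core have been tested in an ADME assay on Huh-5-2 cells (Homo sapiens) for cytotoxicity, read by WST assay, with a stated time of 3 days; on this read-out lower numbers stand for higher toxicity in this test and higher numbers for lower toxicity in this test. Compound 1 `O=c1c(O)c(-c2ccccc2)oc2cc(OCc3ccccc3[N+](=O)[O-])cc(O)c12` carries a 2-nitrophenyl group on a saturated chain carbon bound to an oxygen on an aromatic ring; in this assay compound 1 gives 32000 nM. Compound 2 `O=c1c(O)c(-c2ccccc2)oc2cc(OCc3ccc(Cl)cc3)cc(O)c12` carries a 4-chlorophenyl group in place of that 2-nitrophenyl. For compound 2 this assay reports only a limit, > 100000 nM, and not a number. Between the two there is an at least 3.1-fold higher number from compound 1 to compound 2 (0.49 log units; beyond the scatter), a step that rests on (the limit of > 100000 nM in this assay, at which 1 of the 2 values shown sits). Compound 2 therefore stands at the edge of what this assay can record, without a number of its own.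

Compound 3 `N#Cc1ccc(-c2oc3cc(OCc4ccc(Cl)cc4)cc(O)c3c(=O)c2O)cc1` differs from compound 2 in another part of the molecule: cyano in place of hydrogen on an aromatic carbon. Going by the values given here, no measured step touches that aromatic ring, so nothing here shows how a cyano group placed there moves the read-out. Among the compounds with values here, the only known step changed a different chain and carried the value to the limit. Without evidence either way, the expected step of a number no higher from compound 2 to compound 3 (the limit leaves the size open) is none beyond the scatter. Compound 3 is therefore estimated at 100000 nM, within 35000 nM to 300000 nM, quite possibly again reported only as a limit.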

Compound 3, half-maximal cytotoxic concentration: 67000 nM
For compound 3 the middle estimate is 1.5-fold (0.17 log units) above the measured one; the range from low to high includes it.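

Going by these compounds alone, this is the first look at what a change on this aromatic ring does: in this assay, cyano in place of hydrogen, para to a large group, comes with an at least 1.4-fold lower number from compound 2 to compound 3 (0.17 log units; that floor lies within the scatter). Compound 3 gives 67000 nM, a real number rather than a limit, so with a cyano group at this ring carbon the read-out falls inside the range that the test can record, and that number gives later changes on this ring a firm point of comparison. The floor of the step lies within the usual scatter, so the result does not establish a true drop, and the real size of the step stays unknown because compound 2 has only a limit and not a number: the limit of > 100000 nM in this assay, at which 1 of the 3 values shown sits.

The compounds shown leave open how an amine or a carboxylic acid on this same ring carbon would read in this assay, so one group at one place cannot yet show a trend for the ring. Also open, as far as these compounds go, is whether a cyano group here would move the number in the same way in a compound carrying the 2-nitrophenyl group of compound 1.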